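This account rests on a few compounds, and the source may have more. Where it says the series, first, only, none or still open, it means among the compounds named here.

Compound 3 `O=C(O)Cc1sc(C(c2ccc(F)cc2)c2ccc(F)cc2)nc1-c1cn[nH]c1` carries the shared core with a 1H-pyrazol-4-yl group, and in an in vitro functional assay on HEK285-7 cells for antagonist activity at prostaglandin D2 receptor 2 (Homo sapiens), read by BRET and beta-arrestin recruitment (a lower number here means a stronger inhibitor, a higher number a weaker inhibitor), compound 3 gives 220 nM. Among the three compounds measured so far this is the lowest number, yet it stands close to compound 1 `O=C(O)Cc1sc(C(c2ccc(F)cc2)c2ccc(F)cc2)nc1-c1ccccc1`, which in this assay gives 240 nM; the step of a 1.1-fold lower number from compound 1 to compound 3 (0.04 log units; within the scatter) lies within the scatter. Compound 2 `N#Cc1ccc(-c2nc(C(c3ccc(F)cc3)c3ccc(F)cc3)sc2CC(=O)O)cc1`, bearing a 4-cyanophenyl group, gives 1500 nM in this assay, and the step of a 6.8-fold lower number from compound 2 to compound 3 (0.83 log units; beyond the scatter) is beyond the scatter. Compound 4 `O=C(O)Cc1sc(C(c2ccc(F)cc2)c2ccc(F)cc2)nc1-c1cc(F)nc(F)c1` differs from compound 3 by 2,6-difluoropyridin-4-yl in place of 1H-pyrazol-4-yl on an aromatic carbon. Going by the values given here, two measured steps bear on this change. The exchange of phenyl for 1H-pyrazol-4-yl showed that a five-membered and a six-membered aromatic ring at this place give numbers within the scatter of each other. The addition of a cyano group to the phenyl ring, a 6.3-fold higher number from compound 1 to compound 2 (0.80 log units; beyond the scatter), showed that a substituent on the six-membered ring raised the number. Because the step of a 6.3-fold higher number from compound 1 to compound 2 (0.80 log units; beyond the scatter) went upward when a substituent was added to a six-membered ring, a modest rise in this assay is expected for compound 4, as a 2.7-fold higher number from compound 3 to compound 4 (0.44 log units; beyond the scatter). Compound 4 is therefore estimated at 600 nM, with a range from 200 nM to 2000 nM.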

Compound 4, half-maximal inhibitory concentration: 110 nM
For compound 4 the middle estimate is 5.5-fold (0.74 log units) above the measured one; measured number below the stated range.
By their numbers in this assay, from the lowest: compounds 4, 3 and 1 (each within the scatter of the next, the first and the last beyond it); then compound 2.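

Going by these compounds alone, compound 4 shows that a substituted six-membered ring at this place, the aromatic carbon next to the ring nitrogen, need not raise the number: in this assay the 2,6-difluoropyridin-4-yl group gives a 2.2-fold lower number from compound 1 to compound 4 (0.34 log units; beyond the scatter), whereas the 4-cyanophenyl group, the only substituted ring among the earlier compounds, gave a 6.3-fold higher number from compound 1 to compound 2 (0.80 log units; beyond the scatter). The two substituted rings therefore stand far apart, with a 14-fold lower number from compound 2 to compound 4 (1.13 log units; beyond the scatter), and the comparison with the 1H-pyrazol-4-yl group gives a 2.0-fold lower number from compound 3 to compound 4 (0.30 log units; within the scatter), so a ring with 0 hydrogen-bond donors serves here as well as one with 1. No measurement at hand accounts for the gap between the 4-cyanophenyl and 2,6-difluoropyridin-4-yl groups.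

The compounds shown do not separate the part played by the ring nitrogen of compound 4 from that of its two fluorine atoms; a pyridin-4-yl group without fluorine and a difluorophenyl group would divide the two. From the compounds shown here alone, it also remains open how other substituents on this ring, such as a methoxy group or an amine, would compare in this assay.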